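A few compounds are considered here, and "the series" means these few. Any claim that something is new, unique, unknown or untested is made for them only; others in the source may bear on it.

Measured compounds:
compound 1, `C#CCCCn1c(Cc2cc(OC)c(OC)c(OC)c2)nc2c(N)ncnc21`, 24000 nM
compound 2, `C/C=C/Cn1c(Cc2cc(OC)c(OC)c(OC)c2)nc2c(N)ncnc21`, 51300 nM

Going by the values given here, in a functional assay on MCF7 cells (Homo sapiens) for antiproliferative activity (on this read-out lower numbers stand for stronger inhibition and higher numbers for weaker inhibition), compound 2 has the higher of the two numbers recorded so far, and the only step available to it is a 2.1-fold higher number from compound 1 to compound 2 (0.33 log units; beyond the scatter). Compound 3, `C=CCCn1c(Cc2cc(OC)c(OC)c(OC)c2)nc2c(N)ncnc21`, is not yet measured. It differs from compound 2 by allyl in place of prop-1-en-1-yl on a saturated chain carbon bound to an aromatic nitrogen. Among the compounds with values here, this is a rearrangement of the same atoms rather than a change of chain length, and no measured step covers exactly this kind of change. Within the data shown here, the one measured step, from compound 1 to compound 2, shows that small alterations to this chain move the number by a modest amount. Since compound 3 carries a chain closer in kind to the but-3-yn-1-yl of compound 1, a modest shift back toward that compound's value is expected, as a 1.6-fold lower number from compound 2 to compound 3 (0.20 log units; within the scatter). Compound 3 is therefore estimated at 32000 nM, within a range of 12000 nM to 85000 nM.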

Compound 3, half-maximal inhibitory concentration: 40700 nM
Compound 3: middle estimate off by 1.3-fold (0.10 log units), on the low side; the range from low to high includes it.
By their numbers in this assay, from the lowest: compounds 1, 3 and 2 (each within the scatter of the next, the first and the last beyond it).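

In this assay, allyl in place of prop-1-en-1-yl on a saturated chain carbon bound to an aromatic nitrogen gives a 1.3-fold lower number from compound 2 to compound 3 (0.10 log units; within the scatter), so this rearrangement of the same atoms cannot be told apart from the scatter of repeated measurements. Vinyl in place of propargyl on a saturated chain carbon, two bonds along the chain from an aromatic nitrogen, gives a 1.7-fold higher number from compound 1 to compound 3 (0.23 log units; within the scatter), so the but-3-en-1-yl and but-3-yn-1-yl chains are not separated either, and only a 2.1-fold higher number from compound 1 to compound 2 (0.33 log units; beyond the scatter) lies beyond the scatter. Nothing available explains why the numbers fall as they do.

From the compounds shown here alone, all three compounds carry a chain with a double or triple bond, so it remains open whether a saturated butyl chain, a longer chain, or an amine or carboxylic acid in this place would move the number further. Going by these compounds, whether the same insensitivity would hold with other changes to the shared core also remains open.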